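Adding a hexenyl chain to a methoxy compound

This account rests on a few compounds, and the source may have more. Where it says the series, first, only, none or still open, it means among the compounds named here.

Compound 1 `C=CCCCCOc1ccccc1-c1cnc(OCCC=C)n1C`: 19000 nM
Compound 2 `C=CCCCCOc1ccccc1-c1cnc(OCCCCC=C)n1C`: 9000 nM
Compound 3 `COc1ccccc1-c1cnc(OC)n1C`: > 100000 nM (a limit)

In a functional assay on PC-3 cells (Homo sapiens) for inhibition, read by colorimetric assay and MTT assay, with a stated time of 72 h (a higher number here means a weaker inhibitor, a lower number a stronger inhibitor), compound 3 gives > 100000 nM, which is a limit of the assay and not a number. Any step from compound 3 therefore starts from a loose anchor.

Compound 4 `C=CCCCCOc1ccccc1-c1cnc(OC)n1C` changes one thing: pent-4-en-1-yl in place of hydrogen on a saturated chain carbon bound to an oxygen on an aromatic ring. Put another way, one methoxy becomes (hex-5-en-1-yl)oxy, while the other methoxy stays. Compound 1 and compound 2 both carry this hex-5-en-1-yl chain, and both give real numbers in this assay.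

Going by the values given here, the only measured step is a 2.1-fold lower number from compound 1 to compound 2 (0.32 log units; beyond the scatter). It lies on the other oxygen, where the longer chain goes with the lower number. It does not measure the present change directly, but it offers a hint. Compound 4 has only methoxy on that oxygen, so its number is expected to sit higher than that of compound 1 at 19000 nM. A step down from the limit is still expected, with a size that remains uncertain.

The expected change is an at least 2.5-fold lower number from compound 3 to compound 4 (0.39 log units; beyond the scatter). For compound 4 the estimate is 40000 nM, with an expected range from 15000 nM to 90000 nM.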

Compound 4, half-maximal inhibitory concentration: 86000 nM
The estimate for compound 4 lay 2.2-fold (0.33 log units) below the measured number; low and high end bracket the measured number.
By their numbers in this assay, from the lowest: compound 2; then compound 1; then compound 4. At a limit, above all of these: compound 3.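

Compound 3 gives > 100000 nM in this assay, and this value is a limit of the assay and not a number: the limit of > 100000 nM in this assay, at which 1 of the 4 values shown sits.

Read against that limit, the hex-5-en-1-yl chain in place of methyl gives an at least 1.1-fold lower number from compound 3 to compound 4 (0.06 log units; that floor lies within the scatter), so this change alone is not shown to lower the number by more than the usual scatter. With the hex-5-en-1-yl chain held in place, a methoxy on the other oxygen instead of a longer chain gives a 4.5-fold higher number from compound 1 to compound 4 (0.66 log units; beyond the scatter) and a 9.6-fold higher number from compound 2 to compound 4 (0.98 log units; beyond the scatter), so among compounds 1, 2 and 4 the number falls as the chain on that oxygen grows longer, and none of the three goes against this.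

The compounds shown leave open how far the hex-5-en-1-yl chain really lowers the number from compound 3, and whether a longer chain on the other oxygen would work as well with a plain methoxy in its place. A saturated hexyl chain, or an amine at the end of the chain, would show whether the double bond or the chain length goes with the lower numbers.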